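The compounds below may be only part of what the source reports. "The series", "measured", "known", "first", "only" and "open" are said of these compounds alone.

Compound 1 `CCCCCNc1nc(N)c2nc(O)n(Cc3ccccc3)c2n1`: 0.3 mg/kg
Compound 2 `CCCCCOc1nc(N)c2nc(O)n(Cc3ccccc3)c2n1`: 0.3 mg/kg

In a functional assay on the whole organism for activation, with Mus musculus as the target (a lower number here means that less compound is needed, a higher number that more compound is needed for the effect), compound 2 gives 0.3 mg/kg, level with compound 1 within the usual scatter. Among the compounds with values here, the only measured step, no change at the digits printed from compound 1 to compound 2 (within the scatter), exchanged the atom linking the pentyl chain to the core and left the chain itself as it was. Within the data shown here, compound 3 `COc1nc(N)c2nc(O)n(Cc3ccccc3)c2n1` arises from compound 2 by hydrogen in place of butyl on a saturated chain carbon bound to an oxygen on an aromatic ring, a shortening of that chain, and no measured step speaks to a change of this kind. The data therefore give no direction, so a modest rise in dose is assumed and the range is kept wide. The expected step is a 3.3-fold higher number from compound 2 to compound 3 (0.52 log units; beyond the scatter). Compound 3 is expected to need about 1 mg/kg, estimated between 0.1 mg/kg and 10 mg/kg.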

Compound 3, minimum effective dose: > 1 mg/kg
Compound 3: a limit, no number (the forecaster's own chance of this, stated with the estimate: 15%); the middle value sits exactly at the limit.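

In this assay, the length of the chain on the oxygen matters, whereas exchanging the atom that links it to the core gave no visible change: pentyl to methyl gives an at least 3.3-fold higher number from compound 2 to compound 3 (0.52 log units; beyond the scatter). Methoxy in place of pentylamino likewise gives an at least 3.3-fold higher number from compound 1 to compound 3 (0.52 log units; beyond the scatter). The result for compound 3 is a limit of the assay, not a number: the limit of > 1 mg/kg in this assay, at which 1 of the 3 values shown sits.

The compounds shown leave open how the dose responds to a propyl chain on the oxygen, or to a longer chain such as heptyl. They also leave open what an amine at the end of the pentyl chain would do.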